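The source may report more compounds than this note shows. Statements on the series, on what has been measured and on what is new or still open speak of the compounds shown alone.

Of the compounds shown here, three built on one shared core have been tested in a functional assay on the whole organism for inhibition, with Mus musculus as the target, with a stated time of 1 h, at a dose of 100 mg/kg by the intraperitoneal route; a lower number here means less inhibition, a higher number more inhibition at the dose given (going by the name of the read-out). Compound 1 `Cc1ccccc1NC(=O)Nn1c(C)nc2ccccc2c1=O` gives 51%. Compound 2 `Cc1ccc(NC(=O)Nn2c(C)nc3ccccc3c2=O)cc1` gives 52%. Compound 3 `Cc1nc2ccccc2c(=O)n1NC(=O)Nc1ccc([N+](=O)[O-])cc1` gives 40%, the lowest of the three numbers; it lies under compound 1 and under compound 2 by gaps that are both beyond the usual scatter. Compound 4 `CCc1ccc(NC(=O)Nn2c(C)nc3ccccc3c2=O)cc1` differs from compound 3 in one place: ethyl in place of nitro on an aromatic carbon. Within the data shown here, two measured steps bear on this. Moving the methyl to another position on the phenyl ring gave a number 1 percentage points higher from compound 1 to compound 2 (within the scatter), so that change hardly mattered. Replacing methyl by nitro gave a number 12 percentage points lower from compound 2 to compound 3 (beyond the scatter), a modest loss. Ethyl, like methyl, is a group made only of carbon, so the move from nitro to ethyl looks like the reverse of the step that cost ground, and compound 4 is expected to gain back roughly what was lost, a step of about a number 10 percentage points higher from compound 3 to compound 4 (within the scatter). Compound 4 is therefore estimated to give 50%, with a likely range from 38% to 62%.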

Compound 4, a percentage reported as inhibition, in the whole organism at one dose (the size of the read-out at that dose, not a potency): 53%
For compound 4 the middle estimate is 3 percentage points below the measured one; measured number inside the range.
By their numbers in this assay, from the lowest: compound 3; then compounds 1, 2 and 4 (each within the scatter of the next).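

In this assay, ethyl in place of nitro on this aromatic carbon, para to a large group, gives a number 13 percentage points higher from compound 3 to compound 4 (beyond the scatter), so the drop seen with nitro is also absent with a second group made only of carbon, not just with methyl. Extending methyl to ethyl gives a number 1 percentage points higher from compound 2 to compound 4 (within the scatter), and 4-ethylphenyl in place of 2-methylphenyl gives a number 2 percentage points higher from compound 1 to compound 4 (within the scatter), so neither change can be told apart from the scatter, and among these compounds only the nitro compound stands apart. The data offer no explanation for why nitro differs from these groups.

Going by these compounds, it remains open whether this level would hold with a longer chain such as butyl at the same ring carbon. An amine or a carboxylic acid there could show whether the drop is particular to nitro or extends to other groups containing nitrogen or oxygen.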